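The compounds below may be only part of what the source reports. "The series", "measured", "known", "first", "only" and "open" are said of these compounds alone.

The measured compounds:
Compound 1 `C=CCOc1ccc2c(=O)c(-c3cc(OC)c(OC)cc3OC)coc2c1` gives > 10000 nM in a functional assay on HUVEC cells (Homo sapiens) for antiproliferative activity, read by MTT assay, with a stated time of 24 h (a higher number here means a weaker inhibitor, a lower number a stronger inhibitor), which is a limit of the assay.
Compound 2 `COc1cc(OC)c(-c2coc3cc(OCc4ccc(F)cc4)ccc3c2=O)cc1OC` gives > 10000 nM, also a limit.
Compound 3 `COc1cc(OC)c(-c2coc3cc(OCc4ccccc4C#N)ccc3c2=O)cc1OC` gives > 10000 nM, also a limit.

Compound 1 therefore stands only as a limit, and all three values share it (the limit of > 10000 nM in this assay, at which 3 of the 3 values shown sit). Compound 4 `COc1cc(OC)c(-c2coc3cc(OCc4ccc(Cl)cc4)ccc3c2=O)cc1OC` differs from compound 1 as follows: 4-chlorophenyl in place of vinyl on a saturated chain carbon bound to an oxygen on an aromatic ring. Among the measured compounds shown here, the steps that bear on this change, a step that the two limits leave unreadable from compound 1 to compound 2, a step that the two limits leave unreadable from compound 1 to compound 3 and a step that the two limits leave unreadable from compound 2 to compound 3, are all unreadable, since every value shown is a limit. The series gives no sign that a benzyl group on this oxygen brings activity into range, so he expects compound 4 to remain at the limit, with a step that the limit leaves unreadable from compound 1 to compound 4. His estimate for compound 4 is 15000 nM, between 8000 nM and 40000 nM.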

Compound 4, half-maximal inhibitory concentration: 4400 nM
Compound 4: the middle estimate sits 3.4-fold (0.53 log units) above what was measured; the whole stated range lies above it.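

In this assay, among the compounds shown here, 4-chlorophenyl on a saturated chain carbon bound to an oxygen on an aromatic ring gives the only value that is not a limit, with an at least 2.2-fold lower number from compound 1 to compound 4 (0.35 log units; beyond the scatter) and an at least 2.2-fold lower number from compound 3 to compound 4 (0.35 log units; beyond the scatter). Chloro in place of fluoro on an aromatic carbon alone gives an at least 2.2-fold lower number from compound 2 to compound 4 (0.35 log units; beyond the scatter). The true size of these steps stays unknown, and the steps among compounds 1, 2 and 3 cannot be read: the limit of > 10000 nM in this assay, at which 3 of the 4 values shown sit.

The compounds shown leave open whether bromo or methyl on that aromatic carbon would match chloro. They also leave open whether a benzyl group without chloro would reach a measurable value.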